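One Aryl Swap, Seen Once and Expected Again

This account rests on a few compounds, and the source may have more. Where it says the series, first, only, none or still open, it means among the compounds named here.

Measured compounds:
Compound 1 `Cc1ccc(N(C)CC2CCC/C(=C\c3ccccc3)C2=O)cc1` gives 81% in a functional assay on the whole organism (strain Kunming) for inhibition, with Mus musculus as the target, in the writhing test, with stated times of 1 h and 15 min, at a dose of 200 mg/kg by the oral route; on this read-out lower numbers stand for less inhibition and higher numbers for more inhibition at the one dose given (going by the name of the read-out).
Compound 2 `Cc1cccc(N(C)CC2CCC/C(=C\c3ccccc3)C2=O)c1` gives 76.7% in this assay.
Compound 3 `Cc1ccc(/C=C2\CCCC(CN(C)c3ccc(C)cc3)C2=O)cc1` gives 76.6% in this assay.

Compound 4 `Cc1ccc(/C=C2\CCCC(CN(C)c3cccc(C)c3)C2=O)cc1` has not yet been measured. Compound 3 differs from compound 1 only in its core: methyl in place of hydrogen on an aromatic carbon. Compound 2 carries the change 3-methylphenyl in place of 4-methylphenyl on an amine nitrogen relative to compound 1, and that change gave the step of a number 4.3 percentage points lower from compound 1 to compound 2 (within the scatter). Compound 4 carries the same change relative to compound 3, namely (3-methylphenyl in place of 4-methylphenyl on an amine nitrogen), at a place described in the same words, so it is the same change made on a core that differs by the methyl just noted. Because of a number 4.3 percentage points lower from compound 1 to compound 2 (within the scatter), the step from compound 3 to compound 4 is expected to be about a number 4.1 percentage points lower from compound 3 to compound 4 (within the scatter). On that basis compound 4 is estimated at 72.5%, expected to lie between 62% and 82%.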

Compound 4, a percentage reported as inhibition, in the whole organism at one dose (the size of the read-out at that dose, not a potency): 75.8%
The estimate for compound 4 lay 3.3 percentage points below the measured number, and the stated range covers the measured number.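

In this assay, 3-methylphenyl in place of 4-methylphenyl on the amine nitrogen gave a number 0.8 percentage points lower from compound 3 to compound 4 (within the scatter), and this agrees with the earlier step for the same change: the same change on two cores in this assay, a number 4.3 percentage points lower (within the scatter) from compound 1 to compound 2 and a number 0.8 percentage points lower (within the scatter) from compound 3 to compound 4, 3.5 percentage points apart, within the scatter of two such steps Methyl in place of hydrogen on an aromatic carbon gave a number 0.9 percentage points lower from compound 2 to compound 4 (within the scatter), and this also agrees with its earlier step: the same change on two cores in this assay, a number 4.4 percentage points lower (within the scatter) from compound 1 to compound 3 and a number 0.9 percentage points lower (within the scatter) from compound 2 to compound 4, 3.5 percentage points apart, within the scatter of two such steps This shows that neither change behaved differently on the two cores, but every step is small enough to be scatter, so it does not show that either change has a real effect that carries from one core to another.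

Still open, on these data alone, is whether a chlorine atom or a methoxy group on the aromatic rings would shift the number beyond the scatter. The same question stands for a longer chain in place of the methyl on the amine nitrogen.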